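This account rests on a few compounds, and the source may have more. Where it says the series, first, only, none or still open, it means among the compounds named here.

Measured compounds:
- compound 1, `Cc1cc(C)cc(S(=O)(=O)c2c(C(=O)NC(C)C(=O)NCc3ccccc3F)[nH]c3ccc(Cl)cc23)c1`: 23300 nM
- compound 2, `Cc1cc(C)cc(S(=O)(=O)c2c(C(=O)NCc3cccc(F)c3F)[nH]c3ccc(Cl)cc23)c1`: > 51100 nM

Going by the values given here, in an ADME assay on MT4 cells (Homo sapiens) for cytotoxicity, read by MTT assay (a lower number here means that less compound is tolerated, a higher number that more compound is tolerated), compound 1 gives 23300 nM, the only full number among the two values shown. Compound 2, `Cc1cc(C)cc(S(=O)(=O)c2c(C(=O)NCc3cccc(F)c3F)[nH]c3ccc(Cl)cc23)c1`, reaches only a limit of the assay in this assay, at > 51100 nM, as described by the limit of > 51100 nM in this assay, at which 1 of the 2 values shown sits. Compound 3, `Cc1cc(C)cc(S(=O)(=O)c2c(C(=O)NC(C)c3ccccc3F)[nH]c3ccc(Cl)cc23)c1`, has not yet been measured in this assay; it differs from compound 1 by 2-fluorophenyl in place of (2-fluorobenzyl)carbamoyl on a saturated chain carbon bound to an amide-type nitrogen and a saturated chain carbon. Among the compounds with values here, with no measured step between compounds that differ in one place, the size of this change in this assay is expected to stay within the usual scatter, with a slight lean towards a higher value, that is towards more compound being tolerated; the expected step is a 1.3-fold higher number from compound 1 to compound 3 (0.11 log units; within the scatter). For compound 3 the value in this assay is therefore estimated at 30000 nM, with a range from 10000 nM to 60000 nM.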

Compound 3, half-maximal cytotoxic concentration: > 51500 nM
Compound 3: no number, only a limit; the forecaster's own chance of this, stated with the estimate: 40%; middle value at least 1.7-fold (0.23 log units) from the limit.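

In this assay, 2-fluorophenyl in place of (2-fluorobenzyl)carbamoyl on a saturated chain carbon bound to an amide-type nitrogen and a saturated chain carbon gives an at least 2.2-fold higher number from compound 1 to compound 3 (0.34 log units; beyond the scatter). Compound 3 gives no number, only a limit of the assay: the limit of > 51500 nM in this assay, at which 1 of the 3 values shown sits.

Going by these compounds alone, this single pair is the only readable step at this position, and it shows that more compound is tolerated once the (2-fluorobenzyl)carbamoyl group gives way to 2-fluorophenyl, though the full size of the step stays unknown.

Compound 2 and compound 3 both end at limits, and the step between them cannot be read. As far as these compounds go, it remains open how an amine, a carboxylic acid or a longer chain on this same carbon would compare with compound 1 and compound 3.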